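A few compounds are considered here, and "the series" means these few. Any claim that something is new, unique, unknown or untested is made for them only; others in the source may bear on it.

In an assay on isolated protein for inhibition of thiosulfate sulfurtransferase (Homo sapiens), with a stated time of 60 min, in the absence of a further agent (on this read-out higher numbers stand for weaker inhibition and lower numbers for stronger inhibition), compound 1 `COc1c(Br)cccc1C(=O)Nc1ccc(Sc2nc3ccccc3s2)c(Cl)c1` gives only a limit, > 100000 nM, and not a number. Compound 2 `COc1ccc(Br)cc1C(=O)Nc1ccccc1` also reaches only a limit in this assay, > 100000 nM. Compound 1 thus stands where every value shown stands: at the limit of > 100000 nM in this assay, at which 2 of the 2 values shown sit. Compound 3 `COc1ccccc1C(=O)Nc1ccc(Sc2nc3ccccc3s2)c(Cl)c1` differs from compound 1 by a single change, (hydrogen in place of bromo on an aromatic carbon). Because compound 1 sits at the limit of > 100000 nM in this assay, at which 2 of the 2 values shown sit, the step of a number no higher from compound 1 to compound 3 (the limit leaves the size open) is expected to lie within the usual scatter, with no clear direction. Compound 3 is estimated at 100000 nM, within 30000 nM to 300000 nM, and will most likely again be reported only as a limit.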

Compound 3, half-maximal inhibitory concentration: > 100000 nM
Compound 3 ended at the assay's limit; the forecaster's own chance of this, stated with the estimate: 85%; the middle value sits exactly at the limit.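

In this assay, compound 1 and compound 3 both give a limit and not a number, so no step between them can be read: the limit of > 100000 nM in this assay, at which 3 of the 3 values shown sit.

The compounds shown leave open which structural change, if any, would bring inhibition that can be given as a number.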